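Removing the methoxy from compound 2

The compounds below may be only part of what the source reports. "The series", "measured", "known", "first", "only" and "open" are said of these compounds alone.

In a functional assay on the whole organism for inhibition, with Rattus norvegicus as the target, at a dose of 1 mg/kg by the oral route (a lower number here means a weaker effect, a higher number a stronger effect of the compound at the dose given), compound 2 `CNc1ccc(-c2cc(OC)cc(C(=O)Nc3nn[nH]n3)n2)cc1` gives 35%, and compound 1 `COc1cc(C(=O)Nc2nn[nH]n2)nc(-c2ccc(C(C)(C)C)cc2)c1` gives 29%; the two numbers lie within the usual scatter of each other, so neither stands apart. Compound 3 `CNc1ccc(-c2cccc(C(=O)Nc3nn[nH]n3)n2)cc1` differs from compound 2 by hydrogen in place of methoxy on an aromatic carbon. Within the data shown here, the one measured step, a number 6 percentage points higher from compound 1 to compound 2 (within the scatter), concerns a different position and a different group, so no measured step bears on the removal of the methoxy. Nothing in the data therefore argues for a shift beyond the scatter, and compound 3 is expected to show a number 2 percentage points lower from compound 2 to compound 3 (within the scatter). Compound 3 is estimated at 33%, with a range from 15% to 50%.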

Compound 3, a percentage reported as inhibition, in the whole organism at one dose (the size of the read-out at that dose, not a potency): 71%
For compound 3 the middle estimate is 38 percentage points below the measured one; the measured number lies above the stated range.
By their numbers in this assay, from the lowest: compounds 1 and 2 (each within the scatter of the next); then compound 3.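

The carbon opposite the ring nitrogen is a sensitive point in the series: in this assay, hydrogen in place of methoxy gives a number 36 percentage points higher from compound 2 to compound 3 (beyond the scatter), whereas the change of tert-butyl to methylamino stayed within the scatter. The methoxy is therefore not needed for the effect at this dose, and with the methylamino partner its loss is a clear gain. Nothing available explains this gain. From the compounds shown here alone, it remains open whether a fluorine, a methyl or an amine on this carbon would keep the higher read-out. Going by these compounds, whether the gain from losing the methoxy also holds with tert-butyl in place of methylamino is equally open.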